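A few compounds are considered here, and "the series" means these few. Any claim that something is new, unique, unknown or untested is made for them only; others in the source may bear on it.

In a functional assay on HT-29 cells (Homo sapiens) for cytotoxicity, read by MTT assay, with a stated time of 3 days (on this read-out higher numbers stand for weaker inhibition and lower numbers for stronger inhibition), compound 1 (`COc1cccc(-c2cccc(O)c2)c1`) gives 16 ug/mL, compound 2 (`COc1ccc(-c2cccc(O)c2)cc1`) gives 72 ug/mL and compound 3 (`COc1ccc(-c2ccccc2)cc1OC`) gives 41 ug/mL. Compound 3 thus stands within the scatter of compound 2, while compound 1 has a number lower than compound 3 by more than the scatter. Compound 4 (`COc1ccc(-c2cccc(O)c2)cc1OC`) differs from compound 3 by one change, (hydroxy in place of hydrogen on an aromatic carbon), on an aromatic carbon. Of the two measured compounds carrying a hydroxy group, only compound 1 at 16 ug/mL lies beyond the scatter of compound 3, so the data suggest at most a modest shift. A small move toward a lower number in this assay, within the scatter, is the expected result: a 1.4-fold lower number from compound 3 to compound 4 (0.14 log units; within the scatter). The estimated value for compound 4 is 30 ug/mL, with an expected range from 12 ug/mL to 75 ug/mL.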

Compound 4, half-maximal inhibitory concentration: 29 ug/mL
Beside the measured number, compound 4's estimate is 1.0-fold (0.01 log units) above it; the range from low to high includes it.
By their numbers in this assay, from the lowest: compounds 1, 4, 3 and 2 (each within the scatter of the next, the first and the last beyond it).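

In this assay, hydroxy in place of hydrogen on this aromatic carbon, meta to a large group, gives a 1.4-fold lower number from compound 3 to compound 4 (0.15 log units; within the scatter) and so adds no shift beyond the scatter. An added methoxy group gives a 2.5-fold lower number from compound 2 to compound 4 (0.39 log units; beyond the scatter) in one pair and a 1.8-fold higher number from compound 1 to compound 4 (0.26 log units; within the scatter) in the other, so only the first of these two steps exceeds the scatter. Nothing given here bears on the reason for these steps. From the compounds shown here alone, whether an amine or a carboxylic acid on this same aromatic carbon would move the number remains open.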